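Adding a methyl to compound 2

The compounds below may be only part of what the source reports. "The series", "measured", "known", "first", "only" and "open" are said of these compounds alone.

Compound 1 `Cc1ccnc2nc(-c3ccc4ccccc4c3)cc(O)c12` gives 204 nM
Compound 2 `Cc1ccc2c(O)cc(-c3ccc4ccccc4c3)nc2n1` gives 1950 nM
Compound 3 `Cc1cc(C)c2c(O)cc(-c3ccc4ccccc4c3)nc2n1` is still unmeasured

In a functional assay on MDA-N cells (Homo sapiens) for antiproliferative activity (on this read-out lower numbers stand for stronger inhibition of growth and higher numbers for weaker inhibition of growth), compound 2 gives 1950 nM as the higher of the two numbers, and its gap to compound 1 lies beyond the usual scatter. Compound 3 differs from compound 2 by one change (methyl in place of hydrogen on an aromatic carbon): methyl in place of hydrogen on an aromatic carbon, opposite the ring nitrogen. For the measured compounds named here, no measured step shows this change directly. Compound 1 also carries a methyl opposite the ring nitrogen and gives 204 nM on this read-out, so a lower number than that of compound 2 is expected. The expected change in this assay is a fall beyond the scatter, estimated as a 3.3-fold lower number from compound 2 to compound 3 (0.51 log units; beyond the scatter) on this read-out. Compound 3 is estimated at 600 nM with an expected range from 170 nM to 1900 nM in this measurement.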

Compound 3, concentration for 50% growth inhibition: 3240 nM
Beside the measured number, compound 3's estimate is 5.4-fold (0.73 log units) below it; measured number outside the range, above it.
By their numbers in this assay, from the lowest: compound 1; then compounds 2 and 3 (each within the scatter of the next).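

In this assay, the methyl opposite the ring nitrogen does not by itself bring the lower number seen for compound 1: placed on the core of compound 2, it gives a 1.7-fold higher number from compound 2 to compound 3 (0.22 log units; within the scatter) and so no gain. Compound 1 already carries a methyl opposite the ring nitrogen, yet one further methyl in place of hydrogen on an aromatic carbon gives a 16-fold higher number from compound 1 to compound 3 (1.20 log units; beyond the scatter), so the effect of a methyl here depends on what else the core carries. No measurement on hand explains this.

From the compounds shown here alone, whether an ethyl, an amine or a carboxylic acid opposite the ring nitrogen would move the number on the core of compound 2 remains open. So does whether the same holds for any read-out other than growth inhibition in these cells.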